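A few compounds are considered here, and "the series" means these few. Any claim that something is new, unique, unknown or untested is made for them only; others in the source may bear on it.

Measured so far:
- compound 1, `CONc1nc(C#Cc2ccccc2)nc2c1ncn2[C@H]1[C@H](O)[C@H](O)[C@@H]2C[C@@H]21`: 13 nM
- compound 2, `CCNc1nc(C#Cc2ccccc2Cl)nc2c1ncn2[C@H]1[C@H](O)[C@H](O)[C@@H]2C[C@@H]21`: 5.8 nM

Compound 1 carries a methoxyamino group on its core and a phenylethynyl arm. Within the data shown here, in an assay on CHO cells for displacement of a labelled ligand from adenosine receptor A3 (Homo sapiens), read by scintillation counting, with a stated time of 60 min (on this read-out lower numbers stand for stronger inhibition and higher numbers for weaker inhibition), compound 1 gives 13 nM, the highest of the two numbers known here. Its nearest neighbour, compound 2, which bears an ethylamino group and a chlorine on the phenyl of the ethynyl arm, gives 5.8 nM in this assay, a number beyond the usual scatter below that of compound 1. Among the measured compounds shown here, the two compounds differ in more than one place, so no single step is read from that pair.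

Compound 3, `O[C@@H]1[C@H](O)[C@@H]2C[C@@H]2[C@H]1n1cnc2c(NCc3cccc(Cl)c3)nc(C#Cc3ccccc3)nc21`, keeps the phenylethynyl arm of compound 1 and alters only the amine: 3-chlorobenzyl in place of methoxy on a nitrogen on an aromatic ring. For the measured compounds named here, with no single-point step known between measured compounds, the size of this step can only be estimated. Compound 3 is expected to show a lower number than compound 1, the step of a 4.3-fold lower number from compound 1 to compound 3 (0.64 log units; beyond the scatter) being expected to go beyond the scatter. Compound 3 is estimated to give 3 nM in this assay, within a range of 0.8 nM to 12 nM.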

Compound 3, inhibition constant: 39 nM
Beside the measured number, compound 3's estimate is 13-fold (1.11 log units) below it, outside the stated range (above it).
By their numbers in this assay, from the lowest: compound 2; then compound 1; then compound 3.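

In this assay, among these compounds, the exchange of methoxy for 3-chlorobenzyl on a nitrogen on an aromatic ring gives a 3.0-fold higher number from compound 1 to compound 3 (0.48 log units; beyond the scatter), the first step in this set that can be read at a single place. It shows that the number responds to what sits on this nitrogen, and that here the methoxyamino group of compound 1 gives the lower number of the two, though the step is modest and the group with the six-membered aromatic ring still leaves compound 3 with a measurable affinity. No measurement at hand accounts for this rise.

The compounds shown leave open whether the rise belongs to the aromatic ring, to the chlorine on it or to the loss of the methoxy oxygen, since all three change together in this one step. On these data alone, an unsubstituted benzyl group or a plain methyl group on the same nitrogen, with the phenylethynyl arm kept, would begin to separate these parts, and whether the step holds with another arm on the core also remains open.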